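The compounds below may be only part of what the source reports. "The series", "measured", "known", "first", "only" and "open" are said of these compounds alone.

Measured in an ADME assay on microsomes from liver (Mus musculus) for metabolic stability, read by LC-MS, with a stated time of 10 min, tested at 0.5 uM; on this read-out higher numbers stand for a more stable compound and lower numbers for a less stable compound:
- Compound 1 `c1ccc2c(c1)CN[C@H](CN(CCCN1CCNCC1)[C@H]1CCCc3cccnc31)C2`: 88%
- Compound 2 `CC(C)N1CCN(CCCN(C[C@H]2Cc3ccccc3CN2)[C@H]2CCCc3cccnc32)CC1`: 58%
- Compound 3 `CN1CCN(CCCN(C[C@H]2Cc3ccccc3CN2C)[C@H]2CCCc3cccnc32)CC1`: 43%

Compound 2 stands second of these three, clearly below compound 1 and clearly above compound 3. Compound 4 `c1ccc2c(c1)CN[C@@H](CN(CC[C@H]1CCCNC1)[C@H]1CCCc3cccnc31)C2` differs from compound 2 in one place, (piperidin-3-yl in place of (4-isopropylpiperazin-1-yl)methyl on a saturated chain carbon, two bonds along the chain from an amine nitrogen). Going by the values given here, no measured pair shows this kind of change on its own, so the size of the step is uncertain. Compound 1 lacks the isopropyl group and gives 88%, but compound 3 lacks it too and gives 43%. The expected change in this assay is therefore a moderate rise, a number 12 percentage points higher from compound 2 to compound 4 (beyond the scatter). Compound 4 is estimated at 70%, with an expected range of 48% to 90%.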

Compound 4, percent of the compound remaining: 56%
The estimate for compound 4 lay 14 percentage points above the measured number, within the range that was stated.
By their numbers in this assay, from the lowest: compound 3; then compounds 4 and 2 (each within the scatter of the next); then compound 1.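

In this assay, piperidin-3-yl in place of (4-isopropylpiperazin-1-yl)methyl on a saturated chain carbon, two bonds along the chain from an amine nitrogen, gives a number 2 percentage points lower from compound 2 to compound 4 (within the scatter). This position therefore accepts a group with fewer heavy atoms and a hydrogen-bond donor without a clear shift in this read-out. Nothing measured here offers an explanation for this result. Still open, on these data alone, is whether a cyclohexyl group, with no ring nitrogen, or a morpholine ring would give a similar reading at this position.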